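The source may report more compounds than this note shows. Statements on the series, on what has been measured and on what is new or still open speak of the compounds shown alone.

Among the compounds with values here, in a functional assay on DLD-1 cells (Homo sapiens) for cytotoxicity (on this read-out higher numbers stand for weaker inhibition and lower numbers for stronger inhibition), compound 3 `CCC1C(=O)N(CCCCCCOc2ccc(Cl)cc2)/C(=N\C#N)N1c1ccncc1` gives 3560 nM, the second-highest of the three numbers measured so far. Its nearest neighbour is compound 1 `N#C/N=C1\N(CCCCCCOc2ccc(Cl)cc2)C(=O)CN1c1ccncc1` at 3440 nM, and the furthest is compound 2 `CCC1C(=O)N(CCCCCOc2ccc(Cl)cc2)/C(=N\C#N)N1c1ccncc1` at 4080 nM; both gaps lie within the usual scatter. The step to compound 4 `N#C/N=C1\N(CCCCCCOc2ccc(Cl)cc2)C(=O)C(c2ccccc2)N1c1ccncc1` is phenyl in place of ethyl on a saturated ring carbon. The step that bears most directly on this change is at the same ring carbon, where a 1.0-fold higher number from compound 1 to compound 3 (0.01 log units; within the scatter). The other measured step, a 1.1-fold lower number from compound 2 to compound 3 (0.06 log units; within the scatter), concerns the chain and is less informative. Since a change at this ring carbon produced nothing beyond the scatter, the expectation is a step of about a 1.0-fold higher number from compound 3 to compound 4 (0.00 log units; within the scatter), and compound 4 is estimated at 3600 nM, ranging from 1500 nM to 9000 nM.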

Compound 4, half-maximal inhibitory concentration: 37 nM
Compound 4: middle estimate off by 97-fold (1.99 log units), on the high side; measured number below the stated range.
By their numbers in this assay, from the lowest: compound 4; then compounds 1, 3 and 2 (each within the scatter of the next).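

In this assay, phenyl on this saturated ring carbon brings a 96-fold lower number from compound 3 to compound 4 (1.98 log units; beyond the scatter) when it replaces ethyl and a 93-fold lower number from compound 1 to compound 4 (1.97 log units; beyond the scatter) when it replaces hydrogen, whereas ethyl in place of hydrogen gave a 1.0-fold higher number from compound 1 to compound 3 (0.01 log units; within the scatter). This ring carbon is therefore far from indifferent: what it carries can matter greatly, and the quiet ethyl result did not reveal that. Nothing available explains the gain with phenyl. Still open, from the compounds shown here alone, is whether an aromatic ring is needed here, which cyclohexyl could test, and whether benzyl or 4-chlorophenyl would match phenyl.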